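Swapping a methylphenyl for a nitrofuran on the thiosemicarbazone

The source may hold more compounds than are shown below. What is called first, only, known or untested is meant among the compounds shown, and "the series" means these compounds.

Compound 1 `S=C(N/N=C\c1ccccc1)N(Cc1ccccc1)Cc1ccccc1`: 174000 nM
Compound 2 `Cc1ccccc1/C=N\NC(=S)N(Cc1ccccc1)Cc1ccccc1`: 167000 nM

In an ADME assay on Vero cells (Chlorocebus sabaeus) for cytotoxicity, read by MTT assay, with a stated time of 72 h (a higher number here means that more compound is tolerated, a lower number that less compound is tolerated), compound 2 gives 167000 nM, the lower of the two numbers measured, with compound 1 nearest at 174000 nM; the step of a 1.0-fold lower number from compound 1 to compound 2 (0.02 log units; within the scatter), so the two stand together within the scatter. Compound 3 `O=[N+]([O-])c1ccc(/C=N\NC(=S)N(Cc2ccccc2)Cc2ccccc2)o1` carries a different ring on the shared core: 5-nitrofuran-2-yl in place of 2-methylphenyl on a carbon with a double bond to nitrogen. For the measured compounds named here, the only measured step, a 1.0-fold lower number from compound 1 to compound 2 (0.02 log units; within the scatter), concerns a methyl added to the aromatic ring and says little about exchanging that whole ring for a nitrofuran. Going by the values given here, no measured pair covers this kind of exchange, so the direction cannot be read from the data. Compound 3 is therefore expected to stay near compound 2, with a step of a 1.4-fold lower number from compound 2 to compound 3 (0.14 log units; within the scatter) and wide uncertainty; the estimate for compound 3 is 120000 nM, between 40000 nM and 300000 nM.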

Compound 3, half-maximal cytotoxic concentration: 158000 nM
Compound 3: middle estimate off by 1.3-fold (0.12 log units), on the low side; the measured number falls inside the stated range.
By their numbers in this assay, from the lowest: compounds 3, 2 and 1 (each within the scatter of the next).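

In this assay, the ring on the carbon with a double bond to nitrogen can be exchanged outright, not only given a methyl: 5-nitrofuran-2-yl in place of 2-methylphenyl gives a 1.1-fold lower number from compound 2 to compound 3 (0.02 log units; within the scatter), and the same group in place of phenyl gives a 1.1-fold lower number from compound 1 to compound 3 (0.04 log units; within the scatter). So a five-membered aromatic ring with a hetero atom and hydrogen-bond acceptors, a much larger exchange than the earlier methyl, still leaves all three numbers together. Nothing at hand explains why these numbers stand together.

Going by these compounds, what remains open is whether this position needs an aromatic ring at all. A carboxylic acid, an amine or a longer chain in place of the ring could give a different picture from the three aromatic groups shown here.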